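A Smaller Group on a Compound at the Assay Limit

This account rests on a few compounds, and the source may have more. Where it says the series, first, only, none or still open, it means among the compounds named here.

Of the compounds shown here, three sharing one core have been tested so far in an ADME assay on CCRF-CEM cells (Homo sapiens) for cytotoxicity, with a stated time of 5 days (on this read-out lower numbers stand for stronger inhibition and higher numbers for weaker inhibition), and none gives an exact number. Compound 1 (`COc1nc(NC2CC2)c2ncn([C@H]3C[C@H](N=[N+]=[N-])[C@@H](CO)O3)c2n1`) gives > 100000 nM as its reading, which is a limit of the assay and not a number. Compound 2 (`[N-]=[N+]=N[C@H]1C[C@H](n2cnc3c(NCCCCCO)nc(N)nc32)O[C@@H]1CO`) gives > 100000 nM as its reading, again a limit. Compound 3 (`[N-]=[N+]=N[C@H]1C[C@H](n2cnc3c(NC4CC4)nc(Cl)nc32)O[C@@H]1CO`) gives > 100000 nM as its reading, also a limit, so its true position is not known.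

The next compound is compound 4 (`CNc1nc(Cl)nc2c1ncn2[C@H]1C[C@H](N=[N+]=[N-])[C@@H](CO)O1`), with methyl in place of cyclopropyl on a nitrogen on an aromatic ring. Among the measured compounds shown here, no measured pair makes this same change. For the measured compounds named here, the one measured step is a step that the two limits leave unreadable from compound 1 to compound 3 and it concerns chloro in place of methoxy on an aromatic carbon elsewhere, so it gives no size to carry over.

Going by the values given here, the only guide is that compound 3 and its two relatives sit at the limit of > 100000 nM in this assay, at which 3 of the 3 values shown sit, and so no step beyond the usual scatter, in either direction, is expected in this assay here. The expected step is a number no higher from compound 3 to compound 4 (the limit leaves the size open) in this estimate. Compound 4 is estimated at 100000 nM (expected range 40000 nM to 250000 nM), and it may well be reported only as a limit.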

Compound 4, half-maximal inhibitory concentration: > 100000 nM
Compound 4 ended at the assay's limit; the forecaster's own chance of this, stated with the estimate: 80%; the middle value sits exactly at the limit.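

No size can be read for the change from cyclopropylamino to methylamino between compound 3 and compound 4, because both readings are limits and not numbers: the limit of > 100000 nM in this assay, at which 4 of the 4 values shown sit.

The compounds shown leave open where each true value lies and whether any of these changes on the shared core alters the reading at all.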